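The compounds below may be only part of what the source reports. "The series", "measured", "known", "first", "only" and "open" are said of these compounds alone.

Measured compounds:
compound 1 `CC(/C=N/Nc1nc(N)c2ncn([C@@H]3O[C@H](CO)[C@@H](O)[C@H]3O)c2n1)Cc1ccc(C(C)C)cc1` — in an assay on CHO-K1 cells for displacement of a labelled ligand from adenosine receptor A1 (Homo sapiens), read by scintillation counting, with a stated time of 60 min (on this read-out higher numbers stand for weaker inhibition and lower numbers for stronger inhibition), compound 1 gives 9500 nM
compound 2 `Nc1nc(N/N=C/c2ccc(N3CCCC3)cc2)nc2c1ncn2[C@@H]1O[C@H](CO)[C@@H](O)[C@H]1O` — in this assay compound 2 gives 5.1 nM
compound 3 `Nc1nc(N/N=C/c2cccc(OCc3ccccc3)c2)nc2c1ncn2[C@@H]1O[C@H](CO)[C@@H](O)[C@H]1O` — in this assay compound 3 gives 13 nM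

Compound 2 stands at the lowest number of the three. Compound 3, its nearest neighbour, sits above it by a gap that is beyond the scatter, and compound 1 sits far above both, also beyond the scatter. Both compounds with an aryl hydrazone give low numbers, while compound 1, which carries a branched alkyl chain on the hydrazone carbon, gives a high one.

The unmeasured compound 4 `Nc1nc(N/N=C/c2ccc(Cl)c(C(F)(F)F)c2)nc2c1ncn2[C@@H]1O[C@H](CO)[C@@H](O)[C@H]1O` keeps the shared core and the hydrazone of compound 2 and changes only the aryl group: 4-chloro-3-(trifluoromethyl)phenyl in place of 4-(pyrrolidin-1-yl)phenyl on a carbon with a double bond to nitrogen

Within the data shown here, no step between measured compounds maps directly onto this change. Compounds 2 and 3 show that two differently substituted aryl groups on the hydrazone carbon both give low numbers, so compound 4 is expected to stay in that region. A modest rise is expected for the step from compound 2 to compound 4, roughly a 5.9-fold higher number from compound 2 to compound 4 (0.77 log units; beyond the scatter), and the estimate for compound 4 in this assay is 30 nM, within 8 nM to 120 nM.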

Compound 4, inhibition constant: > 10000 nM
Compound 4 ended at the assay's limit; the forecaster's own chance of this, stated with the estimate: 2%; at least 330-fold (2.52 log units) between middle value and limit.
By their numbers in this assay, from the lowest: compound 2; then compound 3; then compound 1. At a limit, above all of these: compound 4.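

In this assay compound 4 gives > 10000 nM, which is a limit of the assay and not a number. The change to 4-chloro-3-(trifluoromethyl)phenyl on the carbon with a double bond to nitrogen gives an at least 1900-fold higher number from compound 2 to compound 4 (3.29 log units; beyond the scatter), so this position does not accept every aryl group, and the low numbers of compound 2 and compound 3 do not extend to aryl groups in general. The two groups exchanged have the same count of 11 heavy atoms, so group size by that count does not separate them, whereas the group that leaves carries a nitrogen and a hydrogen-bond acceptor and the group that enters carries neither.

The compounds shown do not tell whether the loss follows from removing the pyrrolidine, from adding the chlorine, from adding the trifluoromethyl, or from a combination of these, and the true value of compound 4 remains unknown beyond its limit. A phenyl group bearing chlorine alone or trifluoromethyl alone, or one bearing an open-chain amine such as dimethylamino in place of the pyrrolidine, would begin to separate these possibilities.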